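This account rests on a few compounds, and the source may have more. Where it says the series, first, only, none or still open, it means among the compounds named here.

Working notes on the series. Within the data shown here, compound 2 `Cc1cccc2sc(NC(=O)CCN3CCN(CCCN(C)C)CC3)nc12` gives 570 nM in an assay on membranes from brain for displacement of a labelled ligand from Sigma non-opioid intracellular receptor 1 (Cavia porcellus), read by scintillation counting, with a stated time of 120 min (a higher number here means a weaker inhibitor, a lower number a stronger inhibitor), and stands as the highest of the two numbers so far; the nearest is compound 1 `Cc1cccc2sc(NC(=O)CCN3CCN(C(C)(C)C)CC3)nc12`, with 147 nM. Among the measured compounds shown here, the one measured step, a 3.9-fold higher number from compound 1 to compound 2 (0.59 log units; beyond the scatter), came with a 3-(dimethylamino)propyl replacing a tert-butyl on the ring amine nitrogen. Compound 3 `Cc1cccc2sc(NC(=O)CCN3CCN(C4CCCCC4)CC3)nc12` is not yet measured; it differs from compound 2 by cyclohexyl in place of 3-(dimethylamino)propyl on an amine nitrogen in a ring. Cyclohexyl, like the tert-butyl of compound 1, carries no acceptor, so the step of a 3.9-fold higher number from compound 1 to compound 2 (0.59 log units; beyond the scatter) is expected to be largely reversed. Compound 3 is therefore estimated at 180 nM (range 70 nM to 450 nM), a step of a 3.2-fold lower number from compound 2 to compound 3 (0.50 log units; beyond the scatter) expected to exceed the scatter.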

Compound 3, inhibition constant: 24 nM
Beside the measured number, compound 3's estimate is 7.5-fold (0.88 log units) above it; measured number outside the range, below it.
By their numbers in this assay, from the lowest: compound 3; then compound 1; then compound 2.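

In this assay cyclohexyl on the amine nitrogen in the ring brings a much larger change at this position than any seen before (a 24-fold lower number from compound 2 to compound 3 (1.38 log units; beyond the scatter)), and it also improves on tert-butyl (a 6.1-fold lower number from compound 1 to compound 3 (0.79 log units; beyond the scatter)). Lacking a hydrogen-bond acceptor therefore does not alone set the number here, since compound 1 and compound 3 both lack one yet differ beyond the scatter. No supporting data explain the size of either step.

Still open, from the compounds shown here alone, is whether cyclopentyl, cycloheptyl or phenyl would match cyclohexyl, and whether a dimethylamino group carried on the cyclohexyl ring would give back the loss seen with the 3-(dimethylamino)propyl chain.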